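Chloro additions on the phenyl ring: clearance notes

The source may hold more compounds than are shown below. What is called first, only, known or untested is meant among the compounds shown, and "the series" means these compounds.

The series shares one core and varies the phenyl ring and a saturated ring carbon. Compound 1 is `COc1nc(C2=NOCC(c3ccccc3)N2)ccc1-n1cnc(C)c1`; in an ADME assay on cells (Hepatocyte, Homo sapiens) for pharmacokinetics (on this read-out lower numbers stand for slow clearance and higher numbers for fast clearance), compound 1 gives 21 mL/min/kg. Compound 2 is `COc1nc(C2=NOCC(c3cccc(Cl)c3)N2)ccc1-n1cnc(C)c1`, and in this assay compound 2 gives 15 mL/min/kg. Compound 3 is `COc1nc(C2=NOC(C)C(c3cccc(Cl)c3)N2)ccc1-n1cnc(C)c1`, and in this assay compound 3 gives 19 mL/min/kg. Compound 4, `COc1nc(C2=NOC(C)C(c3ccc(Cl)c(Cl)c3)N2)ccc1-n1cnc(C)c1`, has not yet been measured in this assay.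

The change from compound 1 to compound 2 is chloro in place of hydrogen on an aromatic carbon, and it gave a 1.4-fold lower number from compound 1 to compound 2 (0.15 log units; within the scatter). The change from compound 2 to compound 3 gave a 1.3-fold higher number from compound 2 to compound 3 (0.10 log units; within the scatter). The difference between the cores of compound 1 and compound 3 is not broken down here.

The change from compound 3 to compound 4 is chloro in place of hydrogen on an aromatic carbon. It is the same kind of change as from compound 1 to compound 2, not the same: in compound 2 the entering chloro sits meta to a large group, whereas in compound 4 it sits ortho to a chloro group and para to a large group.

For compound 4 in this assay the step expected is a 1.3-fold lower number from compound 3 to compound 4 (0.10 log units; within the scatter), set beside a 1.4-fold lower number from compound 1 to compound 2 (0.15 log units; within the scatter). Among the measured compounds shown here, this expectation rests on a 1.4-fold lower number from compound 1 to compound 2 (0.15 log units; within the scatter), the only measured instance of this kind of change. The starting point is compound 3 at 19 mL/min/kg. Compound 4 is therefore estimated at 15 mL/min/kg, with an expected range from 9 mL/min/kg to 26 mL/min/kg.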

Compound 4, clearance: 20 mL/min/kg
Estimate against measurement, compound 4: 1.3-fold (0.12 log units) below; the range from low to high includes it.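

In this assay the chloro in place of hydrogen on the phenyl ring of compound 3 gave a 1.1-fold higher number from compound 3 to compound 4 (0.02 log units; within the scatter) and thus no readable shift on this core. This does not show that the change is without effect, nor that it carries over as a fixed step: there are only two instances, the entering chloro sits in a different place in each, and a real shift smaller than the scatter would go unseen on either core. Within those limits, the change carries from the core of compound 1 to the core of compound 3 with no detectable difference between the two steps: the same change on two cores in this assay, a 1.4-fold lower number (0.15 log units; within the scatter) from compound 1 to compound 2 and a 1.1-fold higher number (0.02 log units; within the scatter) from compound 3 to compound 4, 1.5-fold (0.17 log units) apart, within the scatter of two such steps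

The compounds shown leave open whether a group other than chloro on the phenyl ring, such as an amine, a carboxylic acid or a nitrile, would move the clearance read-out beyond the scatter. On these data alone, the saturated ring carbon is equally open, since it carries only hydrogen or methyl here, and a longer chain at that carbon remains an unanswered case for this series.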